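The source may hold more compounds than are shown below. What is called first, only, known or untested is meant among the compounds shown, and "the series" means these compounds.

For the measured compounds named here, compound 2, `O=C1c2ccccc2C(=O)N1C/C=C/Cn1cc(C#CCCc2ccccc2)c(=O)[nH]c1=O`, is the only member of this pair with a number of its own in a functional assay on CCRF-CEM cells (Homo sapiens) for antiproliferative activity, read by MTT assay, with a stated time of 3 days (a higher number here means a weaker inhibitor, a lower number a stronger inhibitor), where compound 2 gives 38000 nM. Compound 1, `CCCCCCCCC#Cc1cn(C/C=C/CN2C(=O)c3ccccc3C2=O)c(=O)[nH]c1=O`, reaches only a limit of this assay, and for compound 1 that limit is > 250000 nM. Going by the values given here, the single measured step, an at least 6.5-fold lower number from compound 1 to compound 2 (0.81 log units; beyond the scatter), is bounded on one side only by the limit of > 250000 nM in this assay, at which 1 of the 2 values shown sits, so its true size is known only as a floor.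

Compound 3, `CCCCC#Cc1cn(C/C=C/CN2C(=O)c3ccccc3C2=O)c(=O)[nH]c1=O`, differs from compound 2 by ethyl in place of phenyl on a saturated chain carbon, two bonds along the chain from a triple-bonded carbon. This undoes the measured step in spirit: the phenyl that separated compound 2 from compound 1 leaves, and an ethyl, shorter than the hexyl of compound 1, enters at the same saturated chain carbon. Only one step bears on this, and it says that a phenyl at this place outperforms a long alkyl chain; whether a short alkyl chain behaves like the long one is not shown. The expectation for compound 3 is therefore a step of a 3.2-fold higher number from compound 2 to compound 3 (0.50 log units; beyond the scatter), toward weaker inhibition, with the chance that the assay again reports only a limit. The estimate for compound 3 in this assay is 120000 nM, within a range of 35000 nM to 250000 nM.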

Compound 3, half-maximal inhibitory concentration: 192000 nM
The estimate for compound 3 lay 1.6-fold (0.20 log units) below the measured number; low and high end bracket the measured number.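

For the compounds shown here, compound 3 gives the first measured number for a short alkyl chain at this place, and it shows that ethyl does not hold what phenyl gives on the saturated chain carbon, two bonds along the chain from a triple-bonded carbon: in this assay the change is a 5.1-fold higher number from compound 2 to compound 3 (0.70 log units; beyond the scatter). Among the three compounds, the phenyl of compound 2 alone reaches the lower number, while the alkyl chains of compound 1 and compound 3 do not, and the comparison of those two chains is an at least 1.3-fold lower number from compound 1 to compound 3 (0.11 log units; that floor lies within the scatter), so chain length is not shown to matter here. Compound 1 gives only a limit of the assay, > 250000 nM, so that comparison has a floor and no true size: the limit of > 250000 nM in this assay, at which 1 of the 3 values shown sits.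

As far as these compounds go, whether the phenyl counts as a ring at all or as an aromatic ring in particular stays open, and a cyclohexyl or a pyridyl group at this place would speak to that. Also open, from the compounds shown here alone, is how a methoxy or a fluorine on the phenyl, or an amine or a carboxylic acid at the end of the chain, would read in this assay.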